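The compounds below may be only part of what the source reports. "The series", "measured", "known", "first", "only" and "open" are said of these compounds alone.

Measured compounds:
compound 1 `COc1cc(OC)c(OC)cc1/C=C/C(=O)c1ccc(Cl)cc1` — 29500 nM
compound 2 `COc1cc(OC)c(OC)cc1/C=C/C(=O)c1cc(OC(C)=O)ccc1OC(C)=O` — 63700 nM
compound 3 `COc1cc(OC)c(C(=O)/C=C/c2cc(OC)c(OC)cc2OC)c(OC)c1` — 51400 nM

In a functional assay on MCF7 cells (Homo sapiens) for inhibition, read by MTT assay, with a stated time of 72 h (a higher number here means a weaker inhibitor, a lower number a stronger inhibitor), compound 1 gives 29500 nM, the lowest of the three numbers. Compound 3, at 51400 nM, sits within the usual scatter of compound 1, so the two cannot be told apart. Compound 2, at 63700 nM, lies beyond the scatter of compound 1 and is the weaker inhibitor of that pair.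

The step considered runs from compound 1 to compound 4 `COc1cc(OC)c(OC)cc1/C=C/C(=O)c1ccc(O)cc1`. The two structures differ in one place: hydroxy in place of chloro on an aromatic carbon. Among the compounds with values here, nothing among the measured compounds shows what this exchange does in this assay, since no two of them differ by only this change. The three numbers all fall in a fairly narrow band, and none of the changes between them is large. Within the data shown here, with no direct precedent, the step from compound 1 to compound 4 is expected to stay within the scatter, perhaps leaning towards a slightly higher number, that is a 1.2-fold higher number from compound 1 to compound 4 (0.07 log units; within the scatter). On that basis compound 4 is estimated to give 35000 nM in this assay, with a likely range from 12000 nM to 100000 nM.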

Compound 4, half-maximal inhibitory concentration: 182000 nM
Estimate against measurement, compound 4: 5.2-fold (0.72 log units) below; the whole stated range lies below it.
By their numbers in this assay, from the lowest: compounds 1, 3 and 2 (each within the scatter of the next, the first and the last beyond it); then compound 4.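

In this assay, hydroxy in place of chloro on an aromatic carbon, para to a large group, gives a 6.2-fold higher number from compound 1 to compound 4 (0.79 log units; beyond the scatter), so this position is not indifferent to the group it carries. Within the data shown here, the earlier compounds included no pair differing in one place and so gave no reading of any single change; this step is the first, it lies beyond the scatter, and it makes the 4-hydroxyphenyl compound the weaker inhibitor of the pair. No evidence is available on why this exchange has this effect.

With only chloro and hydroxy compared at this position, the result cannot show whether the difference depends chiefly on losing chloro or on introducing hydroxy, and an amine, a fluoro or a methyl group on the same carbon could help separate those two readings. On these data alone, it also remains open whether the same exchange would produce a step of similar size on a core carrying other changes, or whether it holds only for the core of compound 1.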